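Methoxy added beside a hydroxy group: expected cytotoxicity

The source may report more compounds than this note shows. Statements on the series, on what has been measured and on what is new or still open speak of the compounds shown alone.

Measured compounds:
compound 1, `COc1ccc(/C=C/C(=O)CC(C)=O)cc1OC`, 18100 nM
compound 2, `COc1ccc(/C=C/C(=O)CC(C)=O)cc1`, 48200 nM
compound 3, `Cc1cc(/C=C/c2ccc(O)cc2)on1`, 88500 nM

All three were tested in an ADME assay on NIH3T3 cells (Mus musculus) for cytotoxicity, read by MTT assay, with a stated time of 72 h; a lower number here means a stronger inhibitor, a higher number a weaker inhibitor. Compound 2 gives 48200 nM, and compound 1 gives 18100 nM, so the change methoxy in place of hydrogen on an aromatic carbon brought a 2.7-fold lower number from compound 2 to compound 1 (0.43 log units; beyond the scatter). The same kind of change is now made to compound 3, giving compound 4, `COc1cc(/C=C/c2cc(C)no2)ccc1O`, through (methoxy in place of hydrogen on an aromatic carbon). The cores of compound 3 and compound 2 are not the same, and the difference between the two cores is not broken down here. The surroundings of the change also differ: in compound 1 the new group sits ortho to a methoxy group (2 heavy atoms), while in compound 4 it sits ortho to a hydroxy group (1 heavy atom). Compound 3 gives 88500 nM in this assay, the highest of the three numbers. Because the earlier step was a 2.7-fold lower number from compound 2 to compound 1 (0.43 log units; beyond the scatter), a step of similar direction but somewhat smaller size is expected here, namely a 2.0-fold lower number from compound 3 to compound 4 (0.29 log units; within the scatter). Compound 4 is therefore estimated at 45000 nM, with a range from 20000 nM to 110000 nM.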

Compound 4, half-maximal inhibitory concentration: > 100000 nM
Compound 4 was reported as a limit; the forecaster's own chance of this, stated with the estimate: 15%; middle value at least 2.2-fold (0.34 log units) from the limit.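

In this assay compound 4 gives > 100000 nM, which is a limit of the assay and not a number. The step is an at least 1.1-fold higher number from compound 3 to compound 4 (0.05 log units; that floor lies within the scatter), so the lower number seen on the core of compound 2 did not carry over to the core of compound 3: the same change on two cores in this assay, a 2.7-fold lower number (0.43 log units; beyond the scatter) from compound 2 to compound 1 and an at least 1.1-fold higher number (0.05 log units; that floor lies within the scatter) from compound 3 to compound 4, at least 3.0-fold (0.47 log units) apart, beyond the scatter of two such steps. This does not show why the two steps part, since the pairs differ both in their core and in the surroundings of the new methoxy, which in compound 4 sits ortho to a hydroxy group, and it does not show how large the step from compound 3 really is: the limit of > 100000 nM in this assay, at which 1 of the 4 values shown sits.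

Still open, as far as these compounds go, is whether a methoxy on the core of compound 3 would give a lower number if the hydroxy group were replaced by a second methoxy, which would separate the core from the surroundings. Also open, from the compounds shown here alone, is how an ethoxy group or a fluorine atom in place of the new methoxy, or an amine in place of the hydroxy group, would read in this assay.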